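The source may report more compounds than this note shows. Statements on the series, on what has been measured and on what is new or still open speak of the compounds shown alone.

Notes on the series. Among the compounds with values here, the common core carries a thiocarbamate nitrogen that bears both an aryl group and an aroyl group, and the three measured members differ in those two arms. In an ADME assay on MT4 cells (Homo sapiens) for cytotoxicity, read by MTT assay (on this read-out lower numbers stand for higher toxicity in this test and higher numbers for lower toxicity in this test), compound 1 `O=C1c2ccccc2C(=O)N1CCOC(=S)N(C(=O)c1cccnc1Cl)c1ccc(Br)cc1` gives only a limit of the assay, > 100000 nM. Compound 2 `Cc1ccc(N(C(=O)c2ccccc2[N+](=O)[O-])C(=S)OCCN2C(=O)c3ccccc3C2=O)cc1` gives 100000 nM in this assay. Compound 3 `O=C1c2ccccc2C(=O)N1CCOC(=S)N(C(=O)c1ccc(F)cc1F)c1ccc(Cl)cc1` gives 52000 nM in this assay; it sits at the lower of the two numbers, but its gap to compound 2 lies within the scatter, so the two are not told apart. Compound 1 adds nothing beyond its limit (the limit of > 100000 nM in this assay, at which 1 of the 3 values shown sits).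

Compound 4 `O=C1c2ccccc2C(=O)N1CCOC(=S)N(C(=O)c1cc([N+](=O)[O-])ccc1Cl)c1ccc(Cl)cc1` has not yet been measured. It differs from compound 3 only at the aroyl arm: 2-chloro-5-nitrophenyl in place of 2,4-difluorophenyl on a carbonyl carbon. Within the data shown here, no step between measured compounds isolates this arm, so the expectation rests on the closeness of compounds 2 and 3 alone. The step of a 1.2-fold higher number from compound 3 to compound 4 (0.06 log units; within the scatter) is expected to stay within the scatter, with no direction claimed. Compound 4 is estimated at 60000 nM in this assay, between 25000 nM and 100000 nM, with a fair chance that only a limit is reported.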

Compound 4, half-maximal cytotoxic concentration: 45000 nM
Compound 4: the middle estimate sits 1.3-fold (0.12 log units) above what was measured, and the stated range covers the measured number.
By their numbers in this assay, from the lowest: compounds 4, 3 and 2 (each within the scatter of the next, the first and the last beyond it).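

The aroyl arm now has its first single-place step in this assay, with 2-chloro-5-nitrophenyl in place of 2,4-difluorophenyl on a carbonyl carbon: a 1.2-fold lower number from compound 3 to compound 4 (0.06 log units; within the scatter). Compound 3 and compound 4 are therefore not told apart, so this one exchange of substituted phenyl groups, with the rest of the molecule held fixed, gives no sign that the aroyl arm moves the read-out. No measured property shown here bears on this result.

On these data alone, whether an amine or a carboxylic acid on the aroyl ring would give a step beyond the scatter remains open. Also open, as far as these compounds go, is whether a change in the aryl arm on the thiocarbamate nitrogen alone, with the aroyl arm held fixed, would shift the number at all.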